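A few compounds are considered here, and "the series" means these few. Any claim that something is new, unique, unknown or untested is made for them only; others in the source may bear on it.

Of the compounds shown here, three have been measured so far in a functional assay on CHO cells for antagonist activity at corticotropin-releasing factor receptor 1 (Homo sapiens), read by cAMP accumulation; on this read-out lower numbers stand for stronger inhibition and higher numbers for weaker inhibition. Compound 1 `COc1ccc(-n2c(C)nc3c(NC(C4CC4)C4CC4)nc(C)nc32)cc1` gives 19 nM, compound 2 `Cc1nc(NC(C2CC2)C2CC2)c2nc(C)n(-c3ccc(F)cc3)c2n1` gives 91 nM, and compound 3 `COc1cc(OC(F)F)ccc1-n1c(C)nc2c(NC(C3CC3)C3CC3)nc(C)nc21` gives 0.291 nM. Compound 1 and compound 2 differ in one place (fluoro in place of methoxy on an aromatic carbon), and the step there was a 4.8-fold higher number from compound 1 to compound 2 (0.68 log units; beyond the scatter). How the core of compound 3 differs from the core of compound 1 is not broken down here. Compound 4 `Cc1nc(NC(C2CC2)C2CC2)c2nc(C)n(-c3ccc(OC(F)F)cc3F)c2n1` differs from compound 3 in one place (fluoro in place of methoxy on an aromatic carbon). This is the same kind of change, but not the same: in compound 1 the changed group sits para to a large group, whereas in compound 3 it sits ortho to a large group and meta to a difluoromethoxy group. Because a 4.8-fold higher number from compound 1 to compound 2 (0.68 log units; beyond the scatter) was modest, compound 4 is expected to land near 1.3 nM in this assay, likely between 0.3 nM and 6 nM. That estimate means a step of a 4.5-fold higher number from compound 3 to compound 4 (0.65 log units; beyond the scatter), with extra width allowed for the different surroundings.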

Compound 4, inhibition constant: 7 nM
For compound 4 the middle estimate is 5.4-fold (0.73 log units) below the measured one; the whole stated range lies below it.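

In this assay, fluoro in place of methoxy gave a 24-fold higher number from compound 3 to compound 4 (1.38 log units; beyond the scatter), so the change weakened inhibition on both cores, but not by the same amount: the same change on two cores in this assay, a 4.8-fold higher number (0.68 log units; beyond the scatter) from compound 1 to compound 2 and a 24-fold higher number (1.38 log units; beyond the scatter) from compound 3 to compound 4, 5.0-fold (0.70 log units) apart, beyond the scatter of two such steps In these two pairs the direction of the step carried over from one core to the other, while its size did not. The changed group also sits in different surroundings in the two pairs, and two pairs cannot show what sets the size or what a third core would do.

The compounds shown leave open what another group in that place, such as chloro, methyl or an amine, would do on the core of compound 3. They also leave open what a trifluoromethoxy group would do in place of the difluoromethoxy group.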